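A few compounds are considered here, and "the series" means these few. Any claim that something is new, unique, unknown or untested is made for them only; others in the source may bear on it.

Of the two compounds measured in a functional assay on MCF7 cells (Homo sapiens) for inhibition, read by MTT assay (a lower number here means a stronger inhibitor of growth, a higher number a weaker inhibitor of growth), compound 1 `COc1cc2oc(-c3cccc(NC(=O)c4ccccc4)c3)cc(=O)c2c(OC)c1OC` gives 12100 nM, and compound 2 `COc1cc2oc(-c3cccc(NC(=O)c4ccc(Cl)cc4)c3)cc(=O)c2c(OC)c1OC` gives 8780 nM; the two lie within the scatter of each other, as the step of a 1.4-fold lower number from compound 1 to compound 2 (0.14 log units; within the scatter) shows. Among the compounds with values here, that step, a change on the same benzoyl ring, is the only measured change that bears on the next one. Compound 3 `COc1ccccc1C(=O)Nc1cccc(-c2cc(=O)c3c(OC)c(OC)c(OC)cc3o2)c1` differs from compound 1 by methoxy in place of hydrogen on an aromatic carbon. Because the comparable step a 1.4-fold lower number from compound 1 to compound 2 (0.14 log units; within the scatter) stayed within the scatter, no step beyond the scatter is expected in this assay here either. Compound 3 is therefore estimated at 10000 nM, within a range of 4000 nM to 25000 nM. That corresponds to an expected step of a 1.2-fold lower number from compound 1 to compound 3 (0.08 log units; within the scatter).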

Compound 3, concentration for 50% growth inhibition: 15300 nM
Compound 3: middle estimate off by 1.5-fold (0.18 log units), on the low side; measured number inside the range.
By their numbers in this assay, from the lowest: compounds 2, 1 and 3 (each within the scatter of the next).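

Methoxy ortho to a large group on the benzoyl ring gives a 1.3-fold higher number from compound 1 to compound 3 (0.10 log units; within the scatter) in this assay, so this position takes the added group without a step beyond the scatter. Replacing 4-chlorophenyl with 2-methoxyphenyl gives a 1.7-fold higher number from compound 2 to compound 3 (0.24 log units; within the scatter) and also stays inside it, so neither chloro nor methoxy has yet separated these compounds. Nothing measured here offers an explanation for this result. Still open, as far as these compounds go, is whether an amine, a carboxylic acid or a longer chain such as butoxy on this ring would produce a step beyond the scatter.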